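The source may hold more compounds than are shown below. What is called first, only, known or untested is meant among the compounds shown, and "the series" means these compounds.

Measured so far in a functional assay on HeLa cells (Homo sapiens) for cytotoxicity, read by MTT assay, with a stated time of 48 h; on this read-out lower numbers stand for stronger inhibition and higher numbers for weaker inhibition:

compound 1, `CC(C)=CCC/C(C)=C/CC/C(C)=C/CC[C@@H]1[C@@]2(C)CCC(=O)C(C)(C)[C@@H]2CC[C@@]1(C)O`: 18300 nM
compound 2, `CC(C)=CCC/C(C)=C/CC/C(C)=C/CC[C@@H]1[C@@]2(C)CC/C(=N\OCc3cn(-c4ccc(F)cc4)nn3)C(C)(C)[C@@H]2CC[C@@]1(C)O`: 21400 nM
compound 3, `CC(C)=CCC/C(C)=C/CC/C(C)=C/CC[C@@H]1[C@@]2(C)C/C(=C\c3ccc(OCc4cn(-c5ccc(F)cc5)nn4)cc3)C(=O)C(C)(C)[C@@H]2CC[C@@]1(C)O`: 126000 nM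

Three compounds of one shared core have been run in this assay. Compound 1 gives 18300 nM and compound 2 gives 21400 nM. Compound 3 gives 126000 nM, the highest number of the three and therefore the weakest of this set: the gap to compound 2, which is the nearest, lies beyond the scatter, and the gap to compound 1, the furthest, lies beyond the scatter as well. Compound 2 and compound 1 lie within the scatter of each other, so nothing can be said of their order.

The next compound in the series, compound 4, is `CC(C)=CCC/C(C)=C/CC/C(C)=C/CC[C@@H]1[C@@]2(C)C/C(=C\c3ccc(OCc4cn(-c5ccncc5)nn4)cc3)C(=O)C(C)(C)[C@@H]2CC[C@@]1(C)O`. It differs from compound 3 in one place: pyridin-4-yl in place of 4-fluorophenyl on an aromatic nitrogen. Within the data shown here, no pair of measured compounds shows this exchange, so there is no measured step to lean on. With only the value of compound 3 as anchor, the author expects no step beyond the scatter for a 1.1-fold lower number from compound 3 to compound 4 (0.06 log units; within the scatter). On that basis compound 4 is estimated at 110000 nM in this assay, with a range from 45000 nM to 280000 nM.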

Compound 4, half-maximal inhibitory concentration: 77600 nM
Compound 4: the middle estimate sits 1.4-fold (0.15 log units) above what was measured, within the range that was stated.
By their numbers in this assay, from the lowest: compounds 1 and 2 (each within the scatter of the next); then compounds 4 and 3 (each within the scatter of the next).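

Among these compounds, the pair of compound 3 and compound 4 gives the first measured reading of the group on the aromatic nitrogen of the five-membered aromatic ring with 3 nitrogen. In this assay, putting pyridin-4-yl in place of 4-fluorophenyl there gives a 1.6-fold lower number from compound 3 to compound 4 (0.21 log units; within the scatter), so the two compounds cannot be told apart on this read-out. Replacing a carbon-only aromatic ring with one that carries a ring nitrogen and a hydrogen-bond acceptor therefore has no effect here that can be distinguished from the scatter, although no measurement is available to explain this result.

With only these two six-membered aromatic rings shown at this position, it remains open whether a different kind of group there, such as a methyl, a benzyl, a 4-aminophenyl or a 4-carboxyphenyl, would give a step beyond the scatter. Going by these compounds, it is also open whether the same exchange would read alike on compound 2, where the 4-fluorophenyl group sits on an oxime-linked side arm.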